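Thiophen-2-yl to 2-methoxyphenyl: an expected half-life

The source may hold more compounds than are shown below. What is called first, only, known or untested is meant among the compounds shown, and "the series" means these compounds.

In a physicochemical assay for pharmacokinetics (a higher number here means that the compound lasts longer, a lower number that the compound disappears faster), the measured compounds give:
Compound 1 `O=C(NCc1ccccc1)N1C(=O)c2ccccc2S1(=O)=O` gives 1.02 h
Compound 2 `O=C(NCc1ccc(Br)cc1)N1C(=O)c2ccccc2S1(=O)=O` gives 0.187 h
Compound 3 `O=C(NCc1cccs1)N1C(=O)c2ccccc2S1(=O)=O` gives 0.365 h

Compound 3 stands level, within the scatter, with one measured neighbour (a 2.0-fold higher number from compound 2 to compound 3 (0.29 log units; within the scatter)) and clear of the other (a 2.8-fold lower number from compound 1 to compound 3 (0.45 log units; beyond the scatter)). Compound 4 `COc1ccccc1CNC(=O)N1C(=O)c2ccccc2S1(=O)=O` carries 2-methoxyphenyl in place of thiophen-2-yl on a saturated chain carbon bound to an amide-type nitrogen. For the measured compounds named here, two measured steps bear on this. Thiophen-2-yl in place of phenyl lowered the number (a 2.8-fold lower number from compound 1 to compound 3 (0.45 log units; beyond the scatter)), so a return to a phenyl ring hints at a rise. Adding a bromo to that phenyl ring lowered it as well (a 5.5-fold lower number from compound 1 to compound 2 (0.74 log units; beyond the scatter)), although a bromo is not a methoxy. These pull in opposite directions, so no change beyond the scatter is expected in this assay. The expected step is small (a 1.4-fold higher number from compound 3 to compound 4 (0.14 log units; within the scatter)). Compound 4 is estimated at 0.5 h (expected range 0.2 h to 1.2 h).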

Compound 4, half-life: 1.12 h
Compound 4: the middle estimate sits 2.2-fold (0.35 log units) below what was measured, within the range that was stated.
By their numbers in this assay, from the lowest: compounds 2 and 3 (each within the scatter of the next); then compounds 1 and 4 (each within the scatter of the next).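

In this assay, the change at this position recovers what thiophen-2-yl had lost (a 3.1-fold higher number from compound 3 to compound 4 (0.49 log units; beyond the scatter)), and adding a methoxy to the phenyl ring leaves the number level (a 1.1-fold higher number from compound 1 to compound 4 (0.04 log units; within the scatter)). A substituent on the phenyl ring therefore need not lower the number, as the exchange of 4-bromophenyl for 2-methoxyphenyl shows (a 6.0-fold higher number from compound 2 to compound 4 (0.78 log units; beyond the scatter)). No measurement shown accounts for this difference between bromo and methoxy. Open, from the compounds shown here alone, is how a fluoro or a hydroxy on the aromatic ring would compare, and whether an amine or a longer chain in place of the ring would hold the number.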